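This account rests on a few compounds, and the source may have more. Where it says the series, first, only, none or still open, it means among the compounds named here.

Among the measured compounds shown here, compound 2 `CC(C)(C)c1ccc(C(=O)NNC(=O)c2cc(I)cc(I)c2O)cc1` is the only member of the series with a numeric reading: in a functional assay on HepG2 cells (Homo sapiens) for cytotoxicity, with a stated time of 24 h (a lower number here means a stronger inhibitor, a higher number a weaker inhibitor), compound 2 gives 87300 nM. Compound 1 `COc1ccc(C(=O)N/N=C/c2cc(I)c(O)c(I)c2)cc1` is recorded only as a limit, > 100000 nM in this assay, and the limit of > 100000 nM in this assay, at which 1 of the 2 values shown sits, marks where it sits. Compound 3 `O=C(NNC(=O)c1cc(I)cc(I)c1O)c1ccc([N+](=O)[O-])cc1` has not been run. Its change from compound 2 is nitro in place of tert-butyl on an aromatic carbon. For the measured compounds named here, no step between measured compounds is available to size this change, so no shift beyond the scatter is expected. The estimated step in this assay is a 1.1-fold higher number from compound 2 to compound 3 (0.06 log units; within the scatter). Compound 3 is expected near 100000 nM, within 40000 nM to 250000 nM, with a fair chance of only a limit being reported.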

Compound 3, half-maximal inhibitory concentration: 159000 nM
The estimate for compound 3 lay 1.6-fold (0.20 log units) below the measured number, within the range that was stated.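

In this assay, among the compounds shown here, nitro in place of tert-butyl on an aromatic carbon, para to a large group, gives a 1.8-fold higher number from compound 2 to compound 3 (0.26 log units; within the scatter), the only sized step. At this position, exchanging an all-carbon group for one of nitrogen and oxygen produces no shift beyond the scatter, and compound 3 still returns a number rather than a limit. Nothing shown bears on the reason for this result. From the compounds shown here alone, whether an amine or a carboxylic acid at this position would move the number beyond the scatter remains open.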